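The compounds below may be only part of what the source reports. "The series", "measured", "known", "first", "only" and "open" are said of these compounds alone.

Measured compounds:
compound 1 `CC(C)(C)OC(=O)NCC1CCCN(C(=O)CN2CN(c3ccccc3)C3(CCN(C(=O)c4ccc(C5CCCCC5)cc4)CC3)C2=O)C1` gives 3800 nM in an assay on HEK293 cells for displacement of a labelled ligand from NPC1-like intracellular cholesterol transporter 1 (Homo sapiens); a lower number here means a stronger inhibitor, a higher number a weaker inhibitor
compound 2 `CC(C)(C)c1ccc(C(=O)N2CCC3(CC2)C(=O)N(CC(=O)NCCCCCNS(C)(=O)=O)CN3c2ccccc2)cc1` gives 5500 nM in this assay
compound 3 `CC(C)(C)OC(=O)NC1CCN(C(=O)CN2CN(c3ccccc3)C3(CCN(C(=O)c4ccc(C5CCCCC5)cc4)CC3)C2=O)CC1` gives 4800 nM in this assay

The three measured compounds share a core and differ in the amide carried by the glycyl arm and in the group on the benzoyl ring. In this assay compound 2 returns the highest of the three numbers, yet the gap to compound 3 and the gap to compound 1 both fall within the usual scatter, so the three compounds cannot be separated on these data; none of them can be called the weakest or the strongest.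

The step to compound 4 `CC1CCCN(C(=O)CN2CN(c3ccccc3)C3(CCN(C(=O)c4ccc(C(C)(C)C)cc4)CC3)C2=O)C1` changes one position of compound 2: 3-methylpiperidin-1-yl in place of (5-(methanesulfonamido)pentyl)amino on a carbonyl carbon. With this change a group that carries donors and acceptors gives way to a ring that carries neither, in the manner of the piperidine amides of compound 1 and compound 3. For the measured compounds named here, no step between measured compounds with a single change is available, so the expectation rests on the narrow spread of the three measured values. The step from compound 2 to compound 4 in this assay is expected to be small, if anything toward a lower number, as a 1.8-fold lower number from compound 2 to compound 4 (0.26 log units; within the scatter). Compound 4 is therefore estimated at 3000 nM, within a range from 1000 nM to 9000 nM.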

Compound 4, half-maximal inhibitory concentration: 12000 nM
Compound 4: the middle estimate sits 4.0-fold (0.60 log units) below what was measured, outside the stated range (above it).
By their numbers in this assay, from the lowest: compounds 1, 3 and 2 (each within the scatter of the next); then compound 4.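

In this assay, for the compounds shown here, 3-methylpiperidin-1-yl in place of (5-(methanesulfonamido)pentyl)amino on a carbonyl carbon gives a 2.2-fold higher number from compound 2 to compound 4 (0.34 log units; beyond the scatter), a modest step, but the first single change in this set and one that lies beyond the scatter, so the group on this carbonyl carbon does affect the number. Compounds 1 and 3 also carry ring amides here, but each differs from compound 4 in more than one place, so they could not show this and do not settle how ring amides behave at this position. Nothing available bears on why the step goes in this direction.

The compounds shown leave open which part of the departing group matters: whether a pentylamino chain ending in an amine or a carboxylic acid instead of the methanesulfonamide would stay close to compound 2, and whether plain piperidin-1-yl would differ from 3-methylpiperidin-1-yl. They also leave open whether the same exchange would give a similar step with cyclohexyl rather than tert-butyl on the benzoyl ring.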